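The source may hold more compounds than are shown below. What is called first, only, known or untested is meant among the compounds shown, and "the series" means these compounds.

Measured so far:
- compound 1, `CCCn1c(=O)[nH]c2nc(-c3ccc(S(=O)(=O)N4CCN(c5ccccc5C)CC4)cc3)[nH]c2c1=O`: in an assay on CHO cells for displacement of a labelled ligand from adenosine receptor A1 (Homo sapiens), read by scintillation counting, with a stated time of 90 min, in the presence of a further agent that is not named here (on this read-out higher numbers stand for weaker inhibition and lower numbers for stronger inhibition), compound 1 gives 419 nM.
- compound 2, `CCCn1c(=O)[nH]c2nc(-c3ccc(S(=O)(=O)N4CCN(c5ccccc5Br)CC4)cc3)[nH]c2c1=O`: compound 2 gives > 1000 nM, which is a limit of this assay, not a number.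
- compound 3, `CCCn1c(=O)[nH]c2nc(-c3ccc(S(=O)(=O)N4CCN(c5cccc(Br)c5)CC4)cc3)[nH]c2c1=O`: compound 3 gives > 1000 nM, again a limit rather than a number.

Compound 3 therefore stands only at the limit of > 1000 nM in this assay, at which 2 of the 3 values shown sit, and no order between compound 2 and compound 3 can be read from that. Two steps lead there from compound 1: an at least 2.3-fold higher number from compound 1 to compound 2 (0.37 log units; beyond the scatter) and an at least 2.3-fold higher number from compound 1 to compound 3 (0.37 log units; beyond the scatter), both at least modest in the direction of weaker inhibition. The step that the two limits leave unreadable from compound 2 to compound 3 stays unreadable.

Compound 4, `CCCn1c(=O)[nH]c2nc(-c3ccc(S(=O)(=O)N4CCN(c5ccccc5)CC4)cc3)[nH]c2c1=O`, has not yet been measured. It differs from compound 3 by hydrogen in place of bromo on an aromatic carbon. Among the compounds with values here, no measured step removes a bromo group, so the size of the change cannot be taken from the data; the only firm point is that compound 1, carrying a methyl group, gives 419 nM. The expected step is an at least 1.4-fold lower number from compound 3 to compound 4 (0.15 log units; that floor lies within the scatter), towards stronger inhibition but of uncertain size. For compound 4 the estimated value is 700 nM, within a range from 250 nM to 3000 nM.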

Compound 4, inhibition constant: 364 nM
For compound 4 the middle estimate is 1.9-fold (0.28 log units) above the measured one, and the stated range covers the measured number.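

Taking the bromo group away gives an at least 2.7-fold lower number from compound 3 to compound 4 (0.43 log units; beyond the scatter) in this assay, and the other bromo compound shows the same with an at least 2.7-fold lower number from compound 2 to compound 4 (0.43 log units; beyond the scatter). Hydrogen and methyl, by contrast, cannot be told apart, with a 1.2-fold lower number from compound 1 to compound 4 (0.06 log units; within the scatter), so among these four compounds it is bromo, not the presence of any group on the ring, that goes with weaker inhibition. Both bromo steps are floors and not true sizes, because each starts from a compound that stands at a limit of the assay: the limit of > 1000 nM in this assay, at which 2 of the 4 values shown sit.

Going by these compounds, how far the two bromo compounds really lie from compound 4 stays unknown, and the step between those two cannot be read. On these data alone, whether fluoro, chloro or methoxy on this ring would behave like bromo or like hydrogen also stays open.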